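Methoxy additions in an imine nitrile series

The source may hold more compounds than are shown below. What is called first, only, known or untested is meant among the compounds shown, and "the series" means these compounds.

Compound 2 `N#Cc1ncn(-c2ccc(F)cc2)c1/N=C/c1ccc(O)cc1` carries a hydroxy-bearing ring on the imine; in a functional assay on MDA-MB-231 cells (Homo sapiens) for antiproliferative activity, read by MTT assay, with a stated time of 48 h (a lower number here means a stronger inhibitor, a higher number a weaker inhibitor), compound 2 gives 16300 nM. Compound 1 `COc1cc(/C=N/c2c(C#N)ncn2-c2ccc(F)cc2)ccc1O` adds a methoxy group; in this assay compound 1 gives 13600 nM. The change from compound 2 to compound 1 is methoxy in place of hydrogen on an aromatic carbon and the step is a 1.2-fold lower number from compound 2 to compound 1 (0.08 log units; within the scatter).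

Compound 3 `COc1ccc(/C=N/c2c(C#N)ncn2Cc2ccc(F)cc2)cc1OC` has a different core, and the difference between the core of compound 3 and the core of compound 2 is not broken down here. In this assay compound 3 gives 10500 nM; compound 3 stands close to both other compounds, within the scatter of each.

Compound 4 `COc1ccc(/C=N/c2c(C#N)ncn2Cc2ccc(F)cc2)c(OC)c1OC` is the unmeasured member. The change from compound 3 to compound 4 is methoxy in place of hydrogen on an aromatic carbon. This is the same kind of change as that from compound 2 to compound 1, not the same: there the entering group was ortho to a hydroxy group and meta to a large group, whereas here it is ortho to a large group, ortho to a methoxy group and meta to a methoxy group.

Among the measured compounds shown here, the one measured instance of this kind of change, a 1.2-fold lower number from compound 2 to compound 1 (0.08 log units; within the scatter), was within the scatter, so the expected step for compound 4 is also small: a 1.2-fold lower number from compound 3 to compound 4 (0.07 log units; within the scatter). Because compound 3 gives 10500 nM, compound 4 is estimated at 9000 nM in this assay, with a range from 4500 nM to 18000 nM.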

Compound 4, half-maximal inhibitory concentration: > 25000 nM
Compound 4 was reported as a limit (the forecaster's own chance of this, stated with the estimate: 5%); at least 2.7-fold (0.44 log units) between middle value and limit.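

In this assay compound 4 gives > 25000 nM, which is a limit of the assay and not a number. On the core of compound 3, methoxy in place of hydrogen on an aromatic carbon gives an at least 2.3-fold higher number from compound 3 to compound 4 (0.37 log units; beyond the scatter), so the change does not carry over unchanged from the core of compound 2: the same change on two cores in this assay, a 1.2-fold lower number (0.08 log units; within the scatter) from compound 2 to compound 1 and an at least 2.3-fold higher number (0.37 log units; beyond the scatter) from compound 3 to compound 4, at least 2.8-fold (0.45 log units) apart, beyond the scatter of two such steps This does not show what sets the two steps apart, since the pairs differ both in core and in where the methoxy enters, here ortho to a large group, ortho to a methoxy group and meta to a methoxy group, and a single pair on each core cannot separate those two differences.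

Still open, on these data alone, is whether the higher number for compound 4 follows from the core or from the place of entry, and how far past the limit its true value lies. Also open, as far as these compounds go, is whether an amine, a fluorine or a carboxylic acid at that same place would follow methoxy on this core, and whether methoxy at that place on the core of compound 2 would give a step like the one seen here.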